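The compounds below may be only part of what the source reports. "The series", "measured", "known", "first", "only" and "open" are said of these compounds alone.

Working notes on the series. Compound 1 `Fc1ccc(OC[C@@H]2CCN2)cn1` gives 0.057 nM in an assay on brain for binding affinity to Neuronal acetylcholine receptor; alpha4/beta2 (Rattus norvegicus), read by radioligand binding; on this read-out higher numbers stand for weaker inhibition and lower numbers for stronger inhibition; compound 2 `c1ccc(-c2ccc(OC[C@@H]3CCN3)cn2)cc1` gives 2.3 nM; compound 3 `Fc1ccc(OC[C@H]2CCN2)cn1` gives 0.066 nM. Compound 3 thus holds the second highest of the three numbers, lying within the scatter of compound 1 and far from compound 2. The step of a 1.2-fold higher number from compound 1 to compound 3 (0.06 log units; within the scatter) stays within the scatter, consistent with the fact that compounds 1 and 3 differ only in the configuration as drawn. Among the measured compounds shown here, the step of a 40-fold higher number from compound 1 to compound 2 (1.61 log units; beyond the scatter) is the only measured change at the same aromatic carbon and is large.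

Compound 4 `COc1ccc(OC[C@H]2CCN2)cn1` differs from compound 3 by methoxy in place of fluoro on an aromatic carbon. Methoxy is a smaller group than the phenyl of compound 2, so a smaller loss than the step of a 40-fold higher number from compound 1 to compound 2 (1.61 log units; beyond the scatter) is expected. For compound 4 the expected step is a 3.0-fold higher number from compound 3 to compound 4 (0.48 log units; beyond the scatter). Compound 4 is therefore estimated at 0.2 nM, with a range from 0.05 nM to 0.8 nM.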

Compound 4, inhibition constant: 0.67 nM
Beside the measured number, compound 4's estimate is 3.4-fold (0.53 log units) below it; low and high end bracket the measured number.
By their numbers in this assay, from the lowest: compounds 1 and 3 (each within the scatter of the next); then compound 4; then compound 2.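

In this assay, the loss at this aromatic carbon next to the ring nitrogen is not peculiar to phenyl: methoxy in place of fluoro gives a 10-fold higher number from compound 3 to compound 4 (1.01 log units; beyond the scatter). Together with a 40-fold higher number from compound 1 to compound 2 (1.61 log units; beyond the scatter), this gives two large steps away from fluoro, both beyond the scatter. These steps start from opposite drawn configurations, and the two fluoro starting points can be set side by side on one ground: (the fact that compounds 1 and 3 differ only in the configuration as drawn).

Going by these compounds, whether chloro or an amine at this carbon would keep the low numbers of compound 1 and compound 3 remains open. Also open, on these data alone, is whether methoxy and phenyl respond to configuration as fluoro does.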